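Capping the hydroxy group of compound 2

The source may hold more compounds than are shown below. What is called first, only, known or untested is meant among the compounds shown, and "the series" means these compounds.

Measured so far in a functional assay on MCF7 cells (Homo sapiens) for cytotoxicity, read by MTT assay, with a stated time of 24 h; on this read-out higher numbers stand for weaker inhibition and lower numbers for stronger inhibition (both entries are limits):
Compound 1 `COc1ccc2c(c1)cc(-c1cc(OC)c(OC)c(OC)c1)n2Cc1ccc(OCc2ccccc2)cc1` gives > 30000 nM as a limit
Compound 2 `COc1ccc2c(c1)cc(-c1cc(OC)c(OC)c(OC)c1)n2Cc1ccc(O)cc1` gives > 30000 nM as a limit

In this assay compound 2 gives > 30000 nM as its reading, which is a limit and not a number. Compound 3 `CCOCC(=O)Oc1ccc(Cn2c(-c3cc(OC)c(OC)c(OC)c3)cc3cc(OC)ccc32)cc1` departs from compound 2 in one place: (ethoxymethyl)carbonyl in place of hydrogen on an oxygen on an aromatic ring, so that hydroxy becomes ((ethoxymethyl)carbonyl)oxy. Going by the values given here, the one measured step on that oxygen is a step that the two limits leave unreadable from compound 1 to compound 2 and it offers no size to build on. Compound 1 and compound 2 both rest on (the limit of > 30000 nM in this assay, at which 2 of the 2 values shown sit), so neither benzyl nor hydrogen on that oxygen has yielded a number. No step beyond the scatter is therefore expected in this assay, no direction can be drawn, and compound 3 may well report only a limit too. The estimated step, a number no higher from compound 2 to compound 3 (the limit leaves the size open), carries that expectation. Compound 3 is estimated at 30000 nM in this assay, with a range of 8000 nM to 60000 nM expected.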

Compound 3, half-maximal inhibitory concentration: > 30000 nM
Compound 3 ended at the assay's limit; the forecaster's own chance of this, stated with the estimate: 70%; the middle value lies on the limit itself.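

In this assay compound 3 gives > 30000 nM, which is a limit and not a number, so its steps from compound 1 and compound 2 cannot be read. The three compounds share one reading: the limit of > 30000 nM in this assay, at which 3 of the 3 values shown sit.

The compounds shown leave open whether any group on that oxygen would yield a number in this assay.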